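A few compounds are considered here, and "the series" means these few. Any claim that something is new, unique, unknown or untested is made for them only; others in the source may bear on it.

In a functional assay on MCF7 cells (Homo sapiens) for inhibition, with a stated time of 48 h (a lower number here means a stronger inhibitor, a higher number a weaker inhibitor), compound 1 (`COc1cc(Sc2c(C)[nH]c3ccc(Cl)cc23)cc(OC)c1OC`) gives 82 nM, compound 2 (`COc1cc(Sc2c[nH]c3ccc(Br)cc23)cc(OC)c1OC`) gives 43 nM and compound 3 (`COc1cc(Sc2c[nH]c3ccc(I)cc23)cc(OC)c1OC`) gives 68 nM. These three numbers lie within the scatter of one another, so compound 3 stands clearly apart from neither of the others. Compound 4 (`COc1cc(Sc2c[nH]c3ccc(N)cc23)cc(OC)c1OC`) carries amino in place of iodo on an aromatic carbon. Within the data shown here, the only measured step at this place is a 1.6-fold higher number from compound 2 to compound 3 (0.20 log units; within the scatter), and it trades one halogen for another, so it offers only weak guidance for an amino group. Among the measured compounds shown here, no amino compound has been measured yet, so a modest rise with wide uncertainty is expected, an estimated 2.2-fold higher number from compound 3 to compound 4 (0.34 log units; beyond the scatter). For compound 4 the estimated value is 150 nM, with an expected range from 30 nM to 700 nM.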

Compound 4, half-maximal inhibitory concentration: 260 nM
Compound 4: the middle estimate sits 1.7-fold (0.24 log units) below what was measured; measured number inside the range.
By their numbers in this assay, from the lowest: compounds 2, 3 and 1 (each within the scatter of the next); then compound 4.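

In this assay this position proves sensitive to the group it carries: unlike the earlier swap of one halogen for another, amino in place of iodo gives a 3.8-fold higher number from compound 3 to compound 4 (0.58 log units; beyond the scatter) and amino in place of bromo gives a 6.0-fold higher number from compound 2 to compound 4 (0.78 log units; beyond the scatter) and both steps lie beyond the scatter. Bromo and iodo therefore sit within the scatter of each other, while amino stands clearly apart from both. No available evidence explains this loss.

From the compounds shown here alone, whether a hydroxyl, methoxy or acetamide group here would match the halogens or the amino compound remains open. So does whether chloro or fluoro would keep the values of bromo and iodo.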